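A few compounds are considered here, and "the series" means these few. Any claim that something is new, unique, unknown or untested is made for them only; others in the source may bear on it.

Measured compounds in an ADME assay on Vero cells (Chlorocebus sabaeus) for cytotoxicity, with a stated time of 5 days; a higher number here means a weaker inhibitor, a lower number a stronger inhibitor:
- compound 1 `O=C(/C=C/c1ccc(N2CCCCC2)cc1)c1cccs1`: 65500 nM
- compound 2 `Cc1ccsc1C(=O)/C=C/c1ccc(N2CCCCC2)cc1`: 63900 nM
- compound 3 `Cc1cc(C(=O)/C=C/c2ccc(N3CCCCC3)cc2)c(C)s1`: 42300 nM

All three share the same core and differ only in the ring on the carbonyl carbon. Compound 3 carries the lowest of the three numbers in this assay, but the steps to it are small: a 1.5-fold lower number from compound 1 to compound 3 (0.19 log units; within the scatter) and a 1.5-fold lower number from compound 2 to compound 3 (0.18 log units; within the scatter), both within the scatter, as is a 1.0-fold lower number from compound 1 to compound 2 (0.01 log units; within the scatter). The three compounds are therefore not separated by these data.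

Compound 4 `O=C(/C=C/c1ccc(N2CCCCC2)cc1)c1ccc(I)s1` is the next member. The change from compound 3 is 5-iodothiophen-2-yl in place of 2,5-dimethylthiophen-3-yl on a carbonyl carbon. Among the compounds with values here, no measured step introduces a halogen on that ring; the only steps that bear on the question are the ones above, which move methyl groups around the thiophene and each stay within the scatter. Nothing in the series indicates that swapping substituents on this ring shifts the cytotoxicity read-out beyond the scatter, so no step beyond it is expected for compound 4 either.

Compound 4 is therefore expected to give about 50000 nM in this assay, with a range from 22000 nM to 110000 nM. The expected step is a 1.2-fold higher number from compound 3 to compound 4 (0.07 log units; within the scatter), that is, essentially flat.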

Compound 4, half-maximal inhibitory concentration: 56500 nM
Beside the measured number, compound 4's estimate is 1.1-fold (0.05 log units) below it; the measured number falls inside the stated range.
By their numbers in this assay, from the lowest: compounds 3, 4, 2 and 1 (each within the scatter of the next).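

Within the data shown here, compound 4 puts a halogen on the thiophene for the first time, and in this assay this change stays within the scatter (a 1.2-fold lower number from compound 1 to compound 4 (0.06 log units; within the scatter)). Set against the methyl-bearing rings, 5-iodothiophen-2-yl is likewise not separated from 3-methylthiophen-2-yl (a 1.1-fold lower number from compound 2 to compound 4 (0.05 log units; within the scatter)) or from 2,5-dimethylthiophen-3-yl (a 1.3-fold higher number from compound 3 to compound 4 (0.13 log units; within the scatter)), so the flat picture at this position on the carbonyl carbon now covers iodo as well as methyl, and all four compounds fit it, with none going against it. No measurement available here bears on what lies behind this flat read-out.

Going by these compounds, whether a carboxylic acid or an amine on this thiophene, or a smaller halogen such as chloro or fluoro, would move the cytotoxicity read-out beyond the scatter remains open. All four compounds also keep the rest of the shared core unchanged, so they give no indication of how the read-out responds to changes away from the ring on the carbonyl carbon.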